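This account rests on a few compounds, and the source may have more. Where it says the series, first, only, none or still open, it means among the compounds named here.

Measured so far in a functional assay on DU-145 cells (Homo sapiens) for cytotoxicity, read by sulforhodamine B assay, with a stated time of 48 h; a higher number here means a weaker inhibitor, a lower number a stronger inhibitor:
compound 1 `C[C@H]1CC[C@@H]2[C@@H](OC(=O)[C@]23CC(c2ccc(Cl)cc2)=NO3)[C@]2(C)C(=O)C=C[C@@]12O` gives 43000 nM;
compound 2 `C[C@H]1CC[C@@H]2[C@@H](OC(=O)[C@]23CC(c2ccccc2Br)=NO3)[C@]2(C)C(=O)C=C[C@@]12O` gives 18000 nM;
compound 3 `C[C@H]1CC[C@@H]2[C@@H](OC(=O)[C@]23CC(c2ccc(O)cc2)=NO3)[C@]2(C)C(=O)C=C[C@@]12O` gives 93000 nM.

Among these three numbers compound 1 stands second highest: compound 3 gives a higher number and compound 2 a lower one, each beyond the scatter. Compound 4 `C[C@H]1CC[C@@H]2[C@@H](OC(=O)[C@]23CC(c2ccc([N+](=O)[O-])cc2)=NO3)[C@]2(C)C(=O)C=C[C@@]12O` differs from compound 1 in one place: nitro in place of chloro on an aromatic carbon. Going by the values given here, two measured steps bear on this, both changing only the group on the aromatic ring: a 2.2-fold higher number from compound 1 to compound 3 (0.34 log units; beyond the scatter) and a 2.4-fold lower number from compound 1 to compound 2 (0.38 log units; beyond the scatter). Both steps are modest and point in opposite directions, so the change to nitro is expected to move this assay by a modest amount at most, with no firm direction. Compound 4 is therefore estimated at 40000 nM, with a range from 15000 nM to 110000 nM, which is expected to mean a 1.1-fold lower number from compound 1 to compound 4 (0.03 log units; within the scatter).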

Compound 4, half-maximal inhibitory concentration: 7000 nM
Compound 4: the middle estimate sits 5.7-fold (0.76 log units) above what was measured; the whole stated range lies above it.
By their numbers in this assay, from the lowest: compound 4; then compound 2; then compound 1; then compound 3.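

In this assay, nitro on this aromatic carbon gives a 6.1-fold lower number from compound 1 to compound 4 (0.79 log units; beyond the scatter) and a 13-fold lower number from compound 3 to compound 4 (1.12 log units; beyond the scatter), so the group here can shift the number much further than chloro and hydroxy alone suggested. Compound 4 also beats the 2-bromophenyl compound, with a 2.6-fold lower number from compound 2 to compound 4 (0.41 log units; beyond the scatter), making it the strongest inhibitor of the four shown. Nothing available explains this gain. Going by these compounds, whether an amine or a nitrile on the same carbon would behave like nitro or like hydroxy stays open. Also open, on these data alone, is whether any other group here could lower the number further.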